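The compounds below may be only part of what the source reports. "The series", "measured", "known", "first", "only" and "open" are said of these compounds alone.

Working notes on the series. For the measured compounds named here, in a physicochemical assay for lipophilicity, read by HPLC, at pH 7.5 (on this read-out higher numbers stand for higher lipophilicity and lower numbers for lower lipophilicity), compound 1 (`CC[C@@H](Nc1c(C#N)c(-c2ccc(-c3cccc(Cl)c3OC)cc2)nc2cnccc12)C(N)=O`) gives 3.1 and compound 2 (`CC[C@@H](Nc1c(C#N)c(-c2ccc(-c3cccc(Cl)c3)cc2)nc2cnccc12)C(N)=O`) gives 3.1 on the same scale, so compound 2 stands level with compound 1, its only measured neighbour. Compound 3 (`CC[C@@H](Nc1c(C#N)c(-c2ccc(-c3ccccc3C(F)(F)F)cc2)nc2cnccc12)C(N)=O`) has yet to be measured in this assay and differs from compound 2 as follows: 2-(trifluoromethyl)phenyl in place of 3-chlorophenyl on an aromatic carbon (2-(trifluoromethyl)phenyl in place of 3-chlorophenyl on an aromatic carbon, para to a large group).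

Going by the values given here, only one measured step bears on this, and only loosely, since it is a different exchange: with no change at the digits printed from compound 1 to compound 2 (within the scatter) for hydrogen in place of methoxy on an aromatic carbon, no step beyond the scatter is expected in this assay and no direction is favoured. Among the compounds with values here, no measured compound carries a trifluoromethyl group, so the range is kept wide. The expected outcome is no change at the digits printed from compound 2 to compound 3 (within the scatter) as an estimate. For compound 3 the estimated value is 3.1 with an expected range from 2.7 to 3.5 for now.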

Compound 3, distribution coefficient: 3.1
The estimate for compound 3 equals the measured number at the digits printed; the measured number falls inside the stated range.
By their numbers in this assay, from the lowest: compounds 1, 2 and 3 (each within the scatter of the next).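

In this assay, the exchange at this position now reaches the whole aryl group rather than a single substituent: 2-(trifluoromethyl)phenyl in place of 3-chlorophenyl gives no change at the digits printed from compound 2 to compound 3 (within the scatter), and 2-(trifluoromethyl)phenyl in place of 3-chloro-2-methoxyphenyl gives no change at the digits printed from compound 1 to compound 3 (within the scatter). The earlier step covered only hydrogen in place of methoxy, whereas these two steps remove the chlorine, bring in a trifluoromethyl group and carry a different substitution pattern on the ring, and all three compounds still stand level on this read-out. Nothing measured alongside these values explains why the read-out stays level across these exchanges.

Every group shown at this position is a phenyl ring with no net charge, so it remains open whether the level would hold with an amine or a carboxylic acid on that ring. Also open, going by these compounds, is how this read-out responds to changes elsewhere on the shared core, such as a longer chain in the arm carrying the amide.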